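Nitro for Fluoro on the Phenyl Tail

The source may report more compounds than this note shows. Statements on the series, on what has been measured and on what is new or still open speak of the compounds shown alone.

Three compounds have been measured in an assay on HEK293 cells for inhibition of acid ceramidase (Homo sapiens), with a stated time of 10 min; on this read-out lower numbers stand for stronger inhibition and higher numbers for weaker inhibition:
compound 1, `O=C(NCCCCc1ccccc1)n1c(=O)oc2ccc([N+](=O)[O-])cc21`, 3 nM
compound 2, `O=C(NCCCCc1ccc(F)cc1)n1c(=O)oc2ccccc21`, 75 nM
compound 3, `O=C(NCCCCc1ccccc1)n1c(=O)oc2ccc(F)cc21`, 12 nM

Compound 3 and compound 1 share a core and differ by nitro in place of fluoro on an aromatic carbon; that change gave a 4.0-fold lower number from compound 3 to compound 1 (0.60 log units; beyond the scatter). Compound 2 differs from compound 3 in the core, and that difference is not broken down here. Compound 4, `O=C(NCCCCc1ccc([N+](=O)[O-])cc1)n1c(=O)oc2ccccc21`, is not yet measured; it differs from compound 2 by nitro in place of fluoro on an aromatic carbon. This is the same kind of change as from compound 3 to compound 1, but the place is not the same: there the group sits on a ring that is part of a fused or bridged system of two rings, meta to a fused ring and para to a fused ring, whereas here it sits para to a large group. From compound 2 to compound 4 a step of a 3.0-fold lower number from compound 2 to compound 4 (0.48 log units; beyond the scatter) is expected in this assay, resting on the earlier step of a 4.0-fold lower number from compound 3 to compound 1 (0.60 log units; beyond the scatter) and kept smaller, the place being different. The estimate for compound 4 in this assay is 25 nM, expected to lie between 8 nM and 80 nM.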

Compound 4, half-maximal inhibitory concentration: 312 nM
For compound 4 the middle estimate is 12-fold (1.10 log units) below the measured one, outside the stated range (above it).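

Nitro in place of fluoro on an aromatic carbon gave a 4.2-fold higher number from compound 2 to compound 4 (0.62 log units; beyond the scatter) in this assay, so the same change moved the number in opposite directions in the two pairs: the same change on two cores in this assay, a 4.0-fold lower number (0.60 log units; beyond the scatter) from compound 3 to compound 1 and a 4.2-fold higher number (0.62 log units; beyond the scatter) from compound 2 to compound 4, 17-fold (1.22 log units) apart, beyond the scatter of two such steps

This shows that the step seen on one core cannot be carried to the other in this series, not even in its direction. It does not show whether the core or the place of the group decides the outcome: the two differ together in these pairs.

The compounds shown leave open whether a nitrile or a methoxy group, para to a large group, would follow the step to compound 4 or the step to compound 1. They also leave open whether a longer chain would alter the size of either step.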